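Bromo-to-fluoro step carried onto a second core

The source may hold more compounds than are shown below. What is called first, only, known or untested is meant among the compounds shown, and "the series" means these compounds.

Compound 1 `O=C(CN1CCN(C(=O)c2cccc(Br)c2)CC1)N1CCN(CCCc2c[nH]c3ccccc23)CC1` and compound 2 `O=C(CN1CCN(C(=O)c2cccc(F)c2)CC1)N1CCN(CCCc2c[nH]c3ccccc23)CC1` share one core; compound 3 `COc1ccc2[nH]cc(CCCN3CCN(C(=O)CN4CCN(C(=O)c5cccc(Br)c5)CC4)CC3)c2c1` and compound 4 `COc1ccc2[nH]cc(CCCN3CCN(C(=O)CN4CCN(C(=O)c5cccc(F)c5)CC4)CC3)c2c1` share another. The two cores differ by methoxy in place of hydrogen on an aromatic carbon, and in an ADME assay on SH-SY5Y cells (Homo sapiens) for cytotoxicity, read by MTT assay, with a stated time of 72 h (a lower number here means a stronger inhibitor, a higher number a weaker inhibitor), that change gives a 1.3-fold higher number from compound 1 to compound 3 (0.12 log units; within the scatter). In this assay compound 1 gives 80500 nM and compound 2 gives 165000 nM. The change between them is fluoro in place of bromo on an aromatic carbon, and it gives a 2.0-fold higher number from compound 1 to compound 2 (0.31 log units; beyond the scatter). Compound 3 gives 105000 nM. Compound 4 is not yet measured; it differs from compound 3 by fluoro in place of bromo on an aromatic carbon. The place of this change reads the same, word for word, as that of the change from compound 1 to compound 2, so it is the same change carried onto the second core, and the change between the two cores itself moved the number only within the scatter. Among the compounds with values here, compound 4 is expected to show a 2.0-fold higher number from compound 3 to compound 4 (0.30 log units; within the scatter), set beside the earlier step, because a 2.0-fold higher number from compound 1 to compound 2 (0.31 log units; beyond the scatter) is the only measured instance of this change. Compound 4 is therefore estimated at 210000 nM, with a range from 120000 nM to 370000 nM.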

Compound 4, half-maximal inhibitory concentration: > 200000 nM
Compound 4: no number, only a limit; the forecaster's own chance of this, stated with the estimate: 25%; the middle value does not contradict the limit.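

In this assay compound 4 gives > 200000 nM, which is a limit of the assay and not a number. Fluoro in place of bromo on the second core gives an at least 1.9-fold higher number from compound 3 to compound 4 (0.27 log units; that floor lies within the scatter), so the result is compatible with the change carrying over from the first core but does not show that its size is kept: the same change on two cores in this assay, a 2.0-fold higher number (0.31 log units; beyond the scatter) from compound 1 to compound 2 and an at least 1.9-fold higher number (0.27 log units; that floor lies within the scatter) from compound 3 to compound 4; the limit leaves it open whether they differ Methoxy in place of hydrogen, read with fluoro on the aromatic ring, gives an at least 1.2-fold higher number from compound 2 to compound 4 (0.08 log units; that floor lies within the scatter), and this comparison is just as unresolved: the same change on two cores in this assay, a 1.3-fold higher number (0.12 log units; within the scatter) from compound 1 to compound 3 and an at least 1.2-fold higher number (0.08 log units; that floor lies within the scatter) from compound 2 to compound 4; the limit leaves it open whether they differ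

The compounds shown leave open whether chloro or trifluoromethyl in place of bromo on the same aromatic carbon would follow the same step on both cores. They also leave open whether hydroxy in place of methoxy, or an amine or a carboxylic acid on that aromatic carbon, would keep the two cores as close in this assay as compound 1 and compound 3 are.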